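Chloro added to compound 3: expected clearance

The compounds below may be only part of what the source reports. "The series", "measured", "known", "first", "only" and "open" are said of these compounds alone.

Measured so far in an ADME assay on microsomes from liver (Homo sapiens) for metabolic stability (on this read-out lower numbers stand for slow clearance and higher numbers for fast clearance), for three compounds:
- compound 1 `CC(=O)N[C@@H]1CCC[C@H](C(=O)Nc2cc(-c3cnn4c3CCCC4)c(Cl)cn2)C1` gives 17 mL.min-1.g-1
- compound 2 `CC(=O)N[C@@H]1CCC[C@H](C(=O)Nc2cc(-c3cnn4c3NCCC4)c(Cl)cn2)C1` gives 6.2 mL.min-1.g-1
- compound 3 `CC(=O)N[C@@H]1CCC[C@H](C(=O)Nc2cc(-c3cnn4c3CC(C)(C)C4)ccn2)C1` gives < 3 mL.min-1.g-1 as a limit

Compound 3 is known only as a limit and not as a number (the limit of < 3 mL.min-1.g-1 in this assay, at which 1 of the 3 values shown sits). Compound 4 `CC(=O)N[C@@H]1CCC[C@H](C(=O)Nc2cc(-c3cnn4c3CC(C)(C)C4)c(Cl)cn2)C1` differs from it by one change chloro in place of hydrogen on an aromatic carbon with chloro in place of hydrogen on an aromatic carbon. For the measured compounds named here, no measured step makes this change directly. Going by the values given here, the one measured step is a 2.7-fold lower number from compound 1 to compound 2 (0.44 log units; beyond the scatter) and it lies in the other ring group, with chloro present on both sides, so it bears only indirectly and gives a modest size for a change in that part of the molecule. Compound 1 gives 17 mL.min-1.g-1 and compound 2 gives 6.2 mL.min-1.g-1 with chloro in place, but neither carries the ring group of compound 3. A modest move towards a higher number is therefore expected, though it may stay close to the scatter. The expected step is an at least 1.6-fold higher number from compound 3 to compound 4 (0.22 log units; that floor lies within the scatter) in this assay on this estimate. For compound 4 the estimate is 5 mL.min-1.g-1 with an expected range from 3 mL.min-1.g-1 to 13 mL.min-1.g-1 (a number rather than a limit is the likelier report).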

Compound 4, intrinsic clearance in microsomes: 50 mL.min-1.g-1
Compound 4: middle estimate off by 10-fold (1.00 log units), on the low side; the measured number lies above the stated range.
By their numbers in this assay, from the lowest: compound 2; then compound 1; then compound 4. At a limit, below all of these: compound 3.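

In this assay, for the compounds shown here, chloro in place of hydrogen on an aromatic carbon, ortho to a large group and para to a large group, gives the first direct reading of this change, and it is a large one: an at least 16-fold higher number from compound 3 to compound 4 (1.22 log units; beyond the scatter). The starting point of that step, compound 3, is a limit and not a number: the limit of < 3 mL.min-1.g-1 in this assay, at which 1 of the 4 values shown sits.

With chloro present in all three compounds, the ring group also counts, as shown by an 8.1-fold higher number from compound 2 to compound 4 (0.91 log units; beyond the scatter) and a 2.9-fold higher number from compound 1 to compound 4 (0.47 log units; beyond the scatter), so the ring group of compound 3 gives no low number in this assay once chloro is in place.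

Still open, as far as these compounds go, is whether fluoro, methyl or a nitrile at this position would give a step of similar size to chloro, or whether the size of the step is particular to chloro. Also open is whether the same hydrogen-to-chloro change has a step of this size on the ring groups of compound 1 and compound 2, where only the chloro side is shown.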